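Notes on a cyano for bromo swap

The source may hold more compounds than are shown below. What is called first, only, known or untested is meant among the compounds shown, and "the series" means these compounds.

In an ADME assay on L6 cells (Rattus norvegicus) for cytotoxicity, read by resazurin assay, with a stated time of 72 h (on this read-out higher numbers stand for weaker inhibition and lower numbers for stronger inhibition), compound 1 (`N#Cc1ccc(C(O)(c2ccc(C(F)(F)F)cc2)c2cccnc2)c(F)c1`) gives 56100 nM and compound 2 (`OC(c1ccc(Cl)cc1)(c1cccnc1)c1ccc(Br)cc1F`) gives 79200 nM, so compound 2 stands level with compound 1 within the scatter. Compound 3 (`N#Cc1ccc(C(O)(c2ccc(Cl)cc2)c2cccnc2)c(F)c1`) carries cyano in place of bromo on an aromatic carbon. Among the compounds with values here, no measured pair isolates this change. Compound 1 also bears cyano and gives 56100 nM, so no step beyond the scatter is expected in this assay. The estimated 1.3-fold lower number from compound 2 to compound 3 (0.11 log units; within the scatter) stays within the scatter. For compound 3 the estimated value is 62000 nM, with an expected range of 30000 nM to 120000 nM.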

Compound 3, half-maximal inhibitory concentration: > 100000 nM
Compound 3: no number, only a limit; the forecaster's own chance of this, stated with the estimate: 10%; middle value at least 1.6-fold (0.20 log units) from the limit.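

In this assay compound 3 reads only as a limit of the assay, > 100000 nM. Cyano in place of bromo gives an at least 1.2-fold higher number from compound 2 to compound 3 (0.10 log units; that floor lies within the scatter), and chloro in place of trifluoromethyl gives an at least 1.7-fold higher number from compound 1 to compound 3 (0.25 log units; that floor lies within the scatter), so each change has only a floor and not a size. This aromatic carbon carries cyano with no sign of stronger inhibition, and the series now reaches the limit of the read-out: the limit of > 100000 nM in this assay, at which 1 of the 3 values shown sits.

Going by these compounds, how far compound 3 lies past its limit stays open, so the two steps cannot be ranked. On these data alone, whether an amine or a carboxylic acid on this aromatic carbon would move the number also stays open.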